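Hydroxy for Chloro: From Compound 3 to Compound 4

The source may report more compounds than this note shows. Statements on the series, on what has been measured and on what is new or still open speak of the compounds shown alone.

Of the compounds shown here, three have been tested in a functional assay on MDA-MB-231 cells (Homo sapiens) for antiproliferative activity, read by MTT assay, with a stated time of 24 h; on this read-out higher numbers stand for weaker inhibition and lower numbers for stronger inhibition. Compound 1 `COc1ccc(-c2noc(-c3ccc(F)cc3)n2)cc1O` reaches only a limit, > 1000000 nM. Compound 2 `COc1cc(-c2noc(-c3ccncc3)n2)ccc1OCc1ccccc1` likewise gives only a limit, > 1000000 nM. Compound 3 `COc1ccc(-c2noc(-c3ccc(Cl)cc3)n2)cc1OC1CCCC1` gives 396000 nM, the only number among the three shown, the other two sitting at the limit of > 1000000 nM in this assay, at which 2 of the 3 values shown sit. Compound 4 `COc1ccc(-c2noc(-c3ccc(O)cc3)n2)cc1OC1CCCC1` differs from compound 3 by hydroxy in place of chloro on an aromatic carbon. For the measured compounds named here, no measured pair differing in one place is available, so there is no basis for expecting a large change in this assay; the step is expected to stay within the scatter or lean slightly toward weaker inhibition. Compound 4 is therefore estimated at 500000 nM, between 150000 nM and 1500000 nM. The expected step is a 1.3-fold higher number from compound 3 to compound 4 (0.10 log units; within the scatter).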

Compound 4, half-maximal inhibitory concentration: 310 nM
Compound 4: middle estimate off by 1600-fold (3.21 log units), on the high side, and the stated range ends above it.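

In this assay, the change from 4-chlorophenyl to 4-hydroxyphenyl gives a 1300-fold lower number from compound 3 to compound 4 (3.11 log units; beyond the scatter), so what sits on this aromatic carbon, para to a large group, matters greatly. For the compounds shown here, this is the first single-place step in the set, and it carries the series far from its weak end: the limit of > 1000000 nM in this assay, at which 2 of the 4 values shown sit. The step alone does not show why one atom counts for so much. As far as these compounds go, whether a methoxy group, an amine or a carboxylic acid in this place would hold the gain stays open. So does whether hydroxy would keep it with the rest of the molecule changed.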